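A few compounds are considered here, and "the series" means these few. Any claim that something is new, unique, unknown or untested is made for them only; others in the source may bear on it.

In a functional assay on HeLa cells (Homo sapiens) for inhibition, read by sulforhodamine B assay (a higher number here means a weaker inhibitor, a lower number a stronger inhibitor), compound 2 (`O=C1C=C(Nc2ccccc2F)C(=O)c2c1nc1n2[C@H]2OC[C@@H](O)[C@H]2OC1`) gives 5120 nM. Compound 1 (`O=C1C(Nc2ccc(Br)cc2)=CC(=O)c2c1nc1n2[C@H]2OC[C@@H](O)[C@H]2OC1`) gives 5220 nM, and compound 3 (`O=C1C(Nc2ccc(C(F)(F)F)cc2)=CC(=O)c2c1nc1n2[C@H]2OC[C@@H](O)[C@H]2OC1`) gives 8920 nM. All three values lie within the scatter of one another, so the measurements do not separate these compounds.

The next compound, compound 4 (`O=C1C=C(Nc2ccc(C(F)(F)F)cc2)C(=O)c2c1nc1n2[C@H]2OC[C@@H](O)[C@H]2OC1`), has not yet been measured. Its difference from compound 2 is 4-(trifluoromethyl)phenyl in place of 2-fluorophenyl on an amine nitrogen. In short, 4-(trifluoromethyl)phenyl stands in place of 2-fluorophenyl on an amine nitrogen.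

For the measured compounds named here, only one measured step bears on this change: a 1.7-fold higher number from compound 1 to compound 3 (0.23 log units; within the scatter), with trifluoromethyl in place of bromo on an aromatic carbon. That step lies within the scatter, and it is only a partial guide. Compound 3 carries the same 4-(trifluoromethyl)phenyl group as compound 4, but the two differ in where the amine nitrogen stands on the shared core. Going by the values given here, no measured pair isolates that difference, and no measured step replaces 2-fluorophenyl directly.

Among the compounds with values here, with a 1.7-fold higher number from compound 1 to compound 3 (0.23 log units; within the scatter) as the only guide, no step beyond the scatter is expected in this assay, though a slight drift towards a higher number is possible. The expected step is a 1.4-fold higher number from compound 2 to compound 4 (0.14 log units; within the scatter). The value for compound 4 is estimated at 7000 nM, with an expected range from 3000 nM to 16000 nM.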

Compound 4, half-maximal inhibitory concentration: > 8000 nM
Compound 4: only a limit was reported; the forecaster's own chance of this, stated with the estimate: 5%; middle value at least 1.1-fold (0.05 log units) away from the limit.
By their numbers in this assay, from the lowest: compounds 2, 1 and 3 (each within the scatter of the next).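

In this assay, for the compounds shown here, the change from 2-fluorophenyl to 4-(trifluoromethyl)phenyl on the amine nitrogen now has a direct reading, which the earlier compounds did not give: an at least 1.5-fold higher number from compound 2 to compound 4 (0.19 log units; that floor lies within the scatter). On these data alone, this step is only a floor, so the true size of the change remains unknown, and it cannot be said whether the change lies within or beyond the scatter. For compound 4, the reported result is a limit and not a number: the limit of > 8000 nM in this assay, at which 1 of the 4 values shown sits.

The compounds shown leave open whether the place of the amine nitrogen on the shared core matters at all, as no pair differs in that alone, and compound 4 cannot be ranked against compound 1 or compound 3 from a limit. They also leave open how this assay would read with a plain phenyl, a phenyl carrying a carboxylic acid or a primary amine, or a longer alkyl chain in place of the aromatic group on this amine nitrogen.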